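The compounds below may be only part of what the source reports. "The series", "measured", "known", "first", "only" and "open" are said of these compounds alone.

Compound 1 `O=C(CCCCCCNC(=O)c1cc(=O)c(O)co1)Nc1ccccc1`, compound 2 `CC(=O)C(=O)NCCCCCCC(=O)Nc1ccccc1` and compound 3 `CC(=O)C(=O)NCCCCC(=O)Nc1ccccc1` were each tested in a functional assay on HCT-116 cells (Homo sapiens) for inhibition, read by colorimetric assay, with a stated time of 3 days; on this read-out lower numbers stand for stronger inhibition and higher numbers for weaker inhibition. Compound 1 reaches only the limit of the assay, > 100000 nM, and no number. Compound 2 likewise gives only the limit > 100000 nM. Compound 3 also gives only the limit > 100000 nM. The change from compound 2 to compound 1 is a group of 8 heavy atoms (5 carbon, 3 oxygen; one six-membered aromatic ring with 1 hetero atom) in place of a group of 3 heavy atoms (2 carbon, 1 oxygen; no ring), on a carbonyl carbon, and the two limits leave its size unreadable: a step that the two limits leave unreadable from compound 2 to compound 1. The difference between the core of compound 3 and the core of compound 2 is not broken down here.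

Compound 4 `O=C(CCCCNC(=O)c1cc(=O)c(O)co1)Nc1ccccc1` has not yet been measured in this assay. It differs from compound 3 by a group of 8 heavy atoms (5 carbon, 3 oxygen; one six-membered aromatic ring with 1 hetero atom) in place of a group of 3 heavy atoms (2 carbon, 1 oxygen; no ring), on a carbonyl carbon, the same change as that from compound 2 to compound 1, made at the same kind of place. The step from compound 3 to compound 4 is expected to be a number no higher from compound 3 to compound 4 (the limit leaves the size open) because every measured value in this set sits at the limit of > 100000 nM in this assay, at which 3 of the 3 values shown sit, leaving no sign that the change moves the read-out. Compound 4 is therefore expected to show 100000 nM, with a range from 30000 nM to 300000 nM, most likely reported again only as a limit.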

Compound 4, half-maximal inhibitory concentration: > 100000 nM
Compound 4: no number, only a limit; the forecaster's own chance of this, stated with the estimate: 80%; the middle value sits exactly at the limit.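

No step can be read between compound 3 and compound 4, since each gives only a limit and not a number: the limit of > 100000 nM in this assay, at which 4 of the 4 values shown sit. The compounds shown leave open whether putting the ring-bearing group in place of the acetyl group, or the difference between their cores, moves this read-out at all.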